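The compounds below may be only part of what the source reports. "The series", "measured", "known", "first", "only" and "open" are said of these compounds alone.

Measured compounds:
compound 1, `COc1ccc2[nH]c(C(=O)N3CC(=O)N(Cc4ccccc4)[C@@H](CN4CCC(C)CC4)C3)cc2c1`, 93100 nM
compound 2, `COc1ccc2[nH]c(C(=O)N3CC(=O)N(Cc4ccccc4)[C@@H](CN4[C@H](C)COC[C@@H]4C)C3)cc2c1`, > 100000 nM

Compound 2 stands at a limit of the assay and not at a number: in a physicochemical assay for solubility, read by spectrophotometry, in phosphate buffer, with a stated time of 2 h, at pH 7.4 (on this read-out lower numbers stand for lower solubility and higher numbers for higher solubility), compound 2 gives > 100000 nM, which is the limit described by the limit of > 100000 nM in this assay, at which 1 of the 2 values shown sits. Within the data shown here, compound 1 lies close to it, and the step of an at least 1.0-fold higher number from compound 1 to compound 2 (0.03 log units; that floor lies within the scatter) is a floor that sits within the scatter, so the one measured change here tells little about direction. Compound 3, `COc1ccc2[nH]c(C(=O)N3CC(=O)N(Cc4ccccc4)[C@@H](CN4CCC5(CCCC5)CC4)C3)cc2c1`, has not yet been measured. It differs from compound 2 by a group of 10 heavy atoms (9 carbon, 1 nitrogen; one five-membered non-aromatic ring of carbon only, one six-membered non-aromatic ring with 1 hetero atom) in place of a group of 8 heavy atoms (6 carbon, 1 nitrogen, 1 oxygen; one six-membered non-aromatic ring with 2 hetero atoms), on a saturated chain carbon bound to a saturated ring carbon. Among the measured compounds shown here, no measured step covers the entering group, so the expectation rests only on the nearby values of compound 1 and compound 2. Compound 3 is expected to come in somewhat lower than compound 2, with the step of an at least 1.8-fold lower number from compound 2 to compound 3 (0.25 log units; that floor lies within the scatter). The estimate for compound 3 is 55000 nM, with a range from 15000 nM to 120000 nM, and a fair chance that this assay again reports only a limit.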

Compound 3, solubility: 5000 nM
Compound 3: middle estimate off by 11-fold (1.04 log units), on the high side; the measured number lies below the stated range.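

At this place, on a saturated chain carbon bound to a saturated ring carbon, the earlier pair gave only a floor within the scatter, whereas in this assay the entering group with its five-membered ring of carbon only gives a 19-fold lower number from compound 1 to compound 3 (1.27 log units; beyond the scatter), a step with a measured number at both ends. The same group in place of 3,5-dimethylmorpholin-4-yl gives an at least 20-fold lower number from compound 2 to compound 3 (1.30 log units; beyond the scatter), which is a floor and still lies beyond the scatter. Compound 2 gives > 100000 nM, a limit of the assay and not a number: the limit of > 100000 nM in this assay, at which 1 of the 3 values shown sits.

The compounds shown leave open whether the step goes with the five-membered ring itself or with the larger group as a whole. They also leave open how a hydroxyl group or a carboxylic acid on the six-membered ring would read at this place.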